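Aryl swap on a sulfonamide series against breast cancer cells

The compounds below may be only part of what the source reports. "The series", "measured", "known", "first", "only" and "open" are said of these compounds alone.

Measured so far:
compound 1 `CC(C)(C)c1ccc(CNCCNS(=O)(=O)c2cc(C(F)(F)F)cc(C(F)(F)F)c2)cc1` with 13000 nM
compound 2 `COc1ccc(CNCCCNS(=O)(=O)c2cc(C(F)(F)F)cc(C(F)(F)F)c2)cc1OC` with 1900 nM
compound 3 `O=S(=O)(NCCNCc1cccc2ccccc12)c1cc(C(F)(F)F)cc(C(F)(F)F)c1` with 18000 nM

The three compounds share a bis(trifluoromethyl)phenyl sulfonamide core and were tested in a functional assay on MCF7 cells (Homo sapiens) for inhibition, read by MTT assay, with a stated time of 72 h; a lower number here means a stronger inhibitor of growth, a higher number a weaker inhibitor of growth. Compound 2 gives the lowest number of the three, and its distance from compound 1 and from compound 3 lies beyond the scatter in each case. Compound 1 and compound 3 differ from compound 2 in more than one place, so only their values can be set side by side. Going by the values given here, the one single-point step among the measured compounds is a 1.4-fold higher number from compound 1 to compound 3 (0.14 log units; within the scatter), which shows that exchanging one aryl group for another on that carbon left this assay essentially unchanged.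

Compound 4 `O=S(=O)(NCCCNCc1ccc(Cl)c(C(F)(F)F)c1)c1cc(C(F)(F)F)cc(C(F)(F)F)c1` is not yet measured. It differs from compound 2 by 4-chloro-3-(trifluoromethyl)phenyl in place of 3,4-dimethoxyphenyl on a saturated chain carbon bound to an amine nitrogen. Among the compounds with values here, the step from compound 1 to compound 3 is the only guide to an aryl exchange here, and it was within the scatter. Compound 4 is therefore expected to sit near compound 2, with a step of a 1.6-fold higher number from compound 2 to compound 4 (0.20 log units; within the scatter) and no clear direction beyond the scatter. For compound 4 the estimate is 3000 nM, within a range from 900 nM to 10000 nM.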

Compound 4, concentration for 50% growth inhibition: 3500 nM
Compound 4: the middle estimate sits 1.2-fold (0.07 log units) below what was measured; the measured number falls inside the stated range.
By their numbers in this assay, from the lowest: compounds 2 and 4 (each within the scatter of the next); then compounds 1 and 3 (each within the scatter of the next).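

In this assay, the exchange on a saturated chain carbon bound to an amine nitrogen gave a 1.8-fold higher number from compound 2 to compound 4 (0.27 log units; within the scatter), so replacing 3,4-dimethoxyphenyl with 4-chloro-3-(trifluoromethyl)phenyl left the number within the scatter. The two groups are far from alike in what they carry: the group that leaves holds 2 oxygen atoms and 2 hydrogen-bond acceptors, while the group that enters holds chlorine and 3 fluorine atoms and 0 hydrogen-bond acceptors, so this position tolerated a change of substituents as well as the aryl exchange already seen between compound 1 and compound 3, and it did so on the chain shared by compound 2 and compound 4. No measurement at hand bears on why this exchange left the number within the scatter.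

No pair shown differs in the chain alone, so the gap between compound 2 and compound 1 cannot be assigned to the chain or to the aryl group. From the compounds shown here alone, it also remains open whether this position would tolerate a group such as a carboxylic acid, a nitrile or a cyclohexyl ring in place of the aryl groups seen so far.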